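Working notes: cytotoxicity of compounds 1 to 4

A few compounds are considered here, and "the series" means these few. Any claim that something is new, unique, unknown or untested is made for them only; others in the source may bear on it.

Measured so far:
Compound 1 `Cc1ccc(NC(=O)c2c(NO)cc(-c3ccc(Cl)cc3)oc2=O)cc1`; in an ADME assay on Huh-7 cells (Homo sapiens) for cytotoxicity, read by a luciferase reporter and WST assay, with a stated time of 3 days (a lower number here means that less compound is tolerated, a higher number that more compound is tolerated), compound 1 gives > 20000 nM, which is a limit of the assay.
Compound 2 `Cc1ccc(NC(=O)c2c(NO)cc(-c3ccc(C)cc3)oc2=O)cc1`; in this assay compound 2 gives > 20000 nM, again a limit.
Compound 3 `CNC(=O)c1c(NO)cc(-c2ccc(Cl)cc2)oc1=O`; in this assay compound 3 gives > 20000 nM, also a limit.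

The change from compound 1 to compound 2 is methyl in place of chloro on an aromatic carbon, and the step it made is a step that the two limits leave unreadable from compound 1 to compound 2. The cores of compound 1 and compound 3 differ by methyl in place of 4-methylphenyl on an amide-type nitrogen, with a step that the two limits leave unreadable from compound 1 to compound 3. All three values sit at the limit of > 20000 nM in this assay, at which 3 of the 3 values shown sit.

Compound 4 `CNC(=O)c1c(NO)cc(-c2ccc(C)cc2)oc1=O` is not yet measured. It differs from compound 3 by methyl in place of chloro on an aromatic carbon, the same change as from compound 1 to compound 2. The step from compound 3 to compound 4 is expected to be a step that the limit leaves unreadable from compound 3 to compound 4, resting on a step that the two limits leave unreadable from compound 1 to compound 2 and on (the limit of > 20000 nM in this assay, at which 3 of the 3 values shown sit). Compound 4 is therefore estimated at 25000 nM in this assay, between 15000 nM and 60000 nM, most likely reported again as a limit.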

Compound 4, half-maximal cytotoxic concentration: > 20000 nM
Compound 4: no number, only a limit (the forecaster's own chance of this, stated with the estimate: 85%); the middle value is on the limit's open side.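

Compound 4 also sits at a limit, so neither its step from compound 3 nor its step from compound 2 can be read: the limit of > 20000 nM in this assay, at which 4 of the 4 values shown sit.

The compounds shown leave open at what concentration any of them becomes cytotoxic, and whether either change alters that concentration.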